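A few compounds are considered here, and "the series" means these few. Any claim that something is new, unique, unknown or untested is made for them only; others in the source may bear on it.

Three compounds have been measured in an ADME assay on HUVEC cells (Homo sapiens) for cytotoxicity, read by MTT assay, with a stated time of 72 h; a higher number here means a weaker inhibitor, a lower number a stronger inhibitor:

Compound 1 `O=C(CCC(=O)OCCCCCCSc1ccc([N+](=O)[O-])c2nonc12)Nc1ccccc1Cl`: 2950 nM
Compound 2 `Cc1ccccc1NC(=O)CCC(=O)OCCCCCCSc1ccc([N+](=O)[O-])c2nonc12`: 1410 nM
Compound 3 `O=C(CCC(=O)OCCCCCCSc1ccc([N+](=O)[O-])c2nonc12)Nc1cccc(Cl)c1`: 1090 nM

Compound 3 has the lowest number of the three. Its nearest neighbour is compound 2, and the difference between them, a 1.3-fold lower number from compound 2 to compound 3 (0.11 log units; within the scatter), lies within the scatter, so the two cannot be ordered. Compound 1 stands furthest away, with a 2.7-fold lower number from compound 1 to compound 3 (0.43 log units; beyond the scatter), a modest step beyond the scatter. The other step among the measured compounds, a 2.1-fold lower number from compound 1 to compound 2 (0.32 log units; beyond the scatter), is of similar modest size.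

Compound 4 `COc1ccc(NC(=O)CCC(=O)OCCCCCCSc2ccc([N+](=O)[O-])c3nonc23)cc1` differs from compound 3 by 4-methoxyphenyl in place of 3-chlorophenyl on an amide-type nitrogen. Going by the values given here, no measured pair shows this particular change. The two steps that touch the same aromatic ring on the amide-type nitrogen, from compound 1 to compound 2 and from compound 1 to compound 3, were both modest, and the step between compound 2 and compound 3 was within the scatter; all three compounds sit in a narrow band. On that basis compound 4 is expected to remain close to compound 3 in this assay, with the step of a 1.4-fold higher number from compound 3 to compound 4 (0.14 log units; within the scatter) expected to stay within or just beyond the scatter. The value of compound 4 is estimated at 1500 nM, within a range from 600 nM to 4000 nM.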

Compound 4, half-maximal inhibitory concentration: 1590 nM
Compound 4: the middle estimate sits 1.1-fold (0.03 log units) below what was measured; the range from low to high includes it.
By their numbers in this assay, from the lowest: compounds 3, 2, 4 and 1 (each within the scatter of the next, the first and the last beyond it).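

In this assay, 4-methoxyphenyl in place of 3-chlorophenyl on the amide-type nitrogen brings in an oxygen and a hydrogen-bond acceptor, yet the result is only a 1.5-fold higher number from compound 3 to compound 4 (0.16 log units; within the scatter), and 4-methoxyphenyl in place of 2-methylphenyl gives a 1.1-fold higher number from compound 2 to compound 4 (0.05 log units; within the scatter), so a ring carrying methoxy cannot be told apart from these two rings in this assay. The comparison with the 2-chlorophenyl compound adds a further point: a 1.9-fold lower number from compound 1 to compound 4 (0.27 log units; within the scatter) also stays inside the scatter, whereas compound 2 and compound 3 each stood beyond it from compound 1, so compound 4 links the four compounds into one continuous band with no clear break among these substituted phenyl groups. Nothing shown gives a measured reason for how little these exchanges change the number.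

The step from compound 3 to compound 4 changes both the group on the ring and its place, so 4-chlorophenyl or 3-methoxyphenyl on the same nitrogen would be needed to separate the two changes. As far as these compounds go, it also remains open whether this flat picture would hold for a ring carrying an amine or a carboxylic acid, or for a cyclohexyl group in place of the phenyl ring.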